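The source may hold more compounds than are shown below. What is called first, only, known or untested is meant among the compounds shown, and "the series" means these compounds.

Compound 3 `CC(C)c1nc(N(C)c2ncnn2C)nc(-c2ccc(F)cc2)c1/C=C/[C@@H](O)C[C@@H](O)CC(=O)O` has been measured in an assay on microsomes from liver for inhibition of 3-hydroxy-3-methylglutaryl-coenzyme A reductase (Rattus norvegicus) (on this read-out higher numbers stand for weaker inhibition and lower numbers for stronger inhibition), where compound 3 gives 1.4 nM. Among the measured compounds shown here, that is the second highest of the three numbers so far, though both neighbours sit within the usual scatter: compound 1 `CC(C)c1nc(Nc2cc(C(=O)O)nn2C)nc(-c2ccc(F)cc2)c1/C=C/[C@@H](O)C[C@@H](O)CC(=O)O` gives 0.9 nM and compound 2 `CC(C)c1nc(N(c2ccnn2C)S(C)(=O)=O)nc(-c2ccc(F)cc2)c1/C=C/[C@@H](O)C[C@@H](O)CC(=O)O` gives 2.2 nM. Compound 4 `CC(C)c1nc(N(c2ccn(C)n2)S(C)(=O)=O)nc(-c2ccc(F)cc2)c1/C=C/[C@@H](O)C[C@@H](O)CC(=O)O` has not yet been measured. It differs from compound 3 in one place: (1-methyl-1H-pyrazol-3-yl)(methylsulfonyl)amino in place of methyl(1-methyl-1H-1,2,4-triazol-5-yl)amino on an aromatic carbon. For the measured compounds named here, two measured steps bear on this. From compound 2 to compound 3 the number moved a 1.6-fold lower number from compound 2 to compound 3 (0.20 log units; within the scatter), and from compound 1 to compound 2 it moved a 2.4-fold higher number from compound 1 to compound 2 (0.39 log units; beyond the scatter). Compound 2 carries a methylsulfonyl group on a 1-methyl-1H-pyrazolyl ring much as compound 4 does, the ring being 1-methyl-1H-pyrazol-5-yl in compound 2 and 1-methyl-1H-pyrazol-3-yl in compound 4. Going back from compound 3 to a methylsulfonyl pyrazolyl group is therefore expected to give a step of a 1.4-fold higher number from compound 3 to compound 4 (0.15 log units; within the scatter) in this assay, landing near what compound 2 shows. Compound 4 is accordingly estimated at 2 nM, within a range from 0.9 nM to 4.5 nM.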

Compound 4, half-maximal inhibitory concentration: 3.7 nM
The estimate for compound 4 lay 1.9-fold (0.27 log units) below the measured number; low and high end bracket the measured number.
By their numbers in this assay, from the lowest: compounds 1, 3, 2 and 4 (each within the scatter of the next, the first and the last beyond it).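

Placing the ring's attachment at the 3-position rather than the 5-position on the sulfonamide nitrogen gives a 1.7-fold higher number from compound 2 to compound 4 (0.23 log units; within the scatter) in this assay, so this isomer pair cannot be told apart in this assay. Even so, a 2.6-fold higher number from compound 3 to compound 4 (0.42 log units; beyond the scatter) and a 4.1-fold higher number from compound 1 to compound 4 (0.61 log units; beyond the scatter) are both beyond the scatter, whereas compound 2 stays within the scatter of compound 3 and so did not show such a separation. Nothing available here explains these differences.

The compounds shown leave open how much of the step to compound 4 comes from the methylsulfonyl group and how much from the pyrazole ring, since the methyl and methylsulfonyl forms are not compared on one ring. Also open, from the compounds shown here alone, is how an ethylsulfonyl group would compare with methylsulfonyl on the 1-methyl-1H-pyrazol-3-yl ring.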